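Adding a Second Methoxy Group: An Expected Step

The source may report more compounds than this note shows. Statements on the series, on what has been measured and on what is new or still open speak of the compounds shown alone.

Compound 1 `O=[N+]([O-])c1ccc2c(c1)S(=O)(=O)N=C2Nc1ccccc1`: 8600 nM
Compound 2 `COc1ccc(NC2=NS(=O)(=O)c3cc([N+](=O)[O-])ccc32)cc1`: 12300 nM

In an assay on isolated protein for inhibition of Polyunsaturated fatty acid 5-lipoxygenase (Homo sapiens), read by fluorescence and spectrophotometry, with a stated time of 10 min (a higher number here means a weaker inhibitor, a lower number a stronger inhibitor), compound 1 gives 8600 nM and compound 2 gives 12300 nM. Compound 2 holds the higher of the two numbers, but the gap a 1.4-fold higher number from compound 1 to compound 2 (0.16 log units; within the scatter) lies within the scatter, so the two are indistinguishable. Compound 3 `COc1ccc(NC2=NS(=O)(=O)c3cc([N+](=O)[O-])ccc32)cc1OC` differs from compound 2 by methoxy in place of hydrogen on an aromatic carbon, placed ortho to a methoxy group and meta to a large group. Among the measured compounds shown here, the one step that bears on this change, a 1.4-fold higher number from compound 1 to compound 2 (0.16 log units; within the scatter), added the first methoxy without a shift beyond the scatter. A similar outcome is expected for a 1.1-fold higher number from compound 2 to compound 3 (0.06 log units; within the scatter). Compound 3 is thus expected to give 14000 nM, between 6000 nM and 35000 nM.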

Compound 3, half-maximal inhibitory concentration: 23500 nM
Compound 3: middle estimate off by 1.7-fold (0.22 log units), on the low side, within the range that was stated.
By their numbers in this assay, from the lowest: compounds 1, 2 and 3 (each within the scatter of the next, the first and the last beyond it).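

On the aromatic carbon ortho to a methoxy group and meta to a large group, the second methoxy gives a small step (a 1.9-fold higher number from compound 2 to compound 3 (0.28 log units; within the scatter)). This position therefore accepts a methoxy alongside the first one, with no shift that can be told from the scatter of repeated measurements. Nothing available accounts for the size of this step. As far as these compounds go, whether an amine or a carboxylic acid in this place would give a different number remains open. So does whether a methoxy here would behave the same way without the first methoxy.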